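Can an acetamido group restore inhibition to compound 2?

The source may report more compounds than this note shows. Statements on the series, on what has been measured and on what is new or still open speak of the compounds shown alone.

In a functional assay on NZB5 cells (Homo sapiens) for inhibition, read by thymidine incorporation, with a stated time of 5 days (on this read-out higher numbers stand for weaker inhibition and lower numbers for stronger inhibition), compound 2 `Cc1ccccc1S(=O)(=O)N(C)/N=C/c1cnn2ccc(C#N)cc12` gives > 20000 nM, which is a limit of the assay and not a number. Its bromo-bearing relative, compound 1 `Cc1ccc(Br)cc1S(=O)(=O)N(C)/N=C/c1cnn2ccc(C#N)cc12`, gives 700 nM in this assay. Swapping that bromo for hydrogen produces an at least 28-fold higher number from compound 1 to compound 2 (1.45 log units; beyond the scatter), a large step beyond the scatter and the only measured step that bears on what follows. Compound 3 `CC(=O)Nc1ccc(C)c(S(=O)(=O)N(C)/N=C/c2cnn3ccc(C#N)cc23)c1` alters compound 2 on the same ring carbon, with acetamido in place of hydrogen on an aromatic carbon. Acetamido is a different group from bromo, so compound 1 at 700 nM guides the direction more than the size. The estimated step is an at least 10-fold lower number from compound 2 to compound 3 (1.00 log units; beyond the scatter), towards stronger inhibition, although a result at the limit remains possible. Compound 3 is estimated at 2000 nM, with an expected range of 200 nM to 20000 nM.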

Compound 3, half-maximal inhibitory concentration: > 20000 nM
Compound 3 gave a limit, no number; the forecaster's own chance of this, stated with the estimate: 25%; middle value at least 10-fold (1.00 log units) from the limit.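

In this assay, acetamido on this ring carbon, para to a methyl group, does not take over the role of bromo: putting it where bromo stands gives an at least 28-fold higher number from compound 1 to compound 3 (1.45 log units; beyond the scatter). Compound 3 reads > 20000 nM, which is a limit of the assay and not a number, so of the groups shown on this carbon, only bromo gives a measurable value. The step between the compounds without bromo and with acetamido cannot be read, because both values are limits and neither can be placed against the other: the limit of > 20000 nM in this assay, at which 2 of the 3 values shown sit.

Going by these compounds, whether bromo is unusual here or acetamido is simply unsuited to this carbon remains open. Chloro, methoxy or an amine on the same carbon would help separate these two readings, provided any of them gave a value inside the range of the assay.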